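A Second Hydroxy Group on the Styryl Side

A few compounds are considered here, and "the series" means these few. Any claim that something is new, unique, unknown or untested is made for them only; others in the source may bear on it.

All three measured compounds were tested in an assay on isolated protein for inhibition of Alpha glucosidase (Homo sapiens), with stated times of 5 min and 15 min, tested at 50 uM (a higher number here means more inhibition at the concentration tested (going by the name of the read-out), a lower number less inhibition), and gave these numbers:
Compound 1, `O=C(/C=C(O)/C=C/c1ccc(O)c(O)c1)c1ccccc1O`: 93.6%
Compound 2, `O=C(/C=C(O)/C=C/c1ccc(O)cc1)c1cc(Cl)ccc1O`: 45.3%
Compound 3, `O=C(/C=C(O)/C=C/c1ccc(O)cc1)c1ccccc1O`: 20.4%

Compound 3 stands lowest of the three. Its nearest neighbour is compound 2, separated by a number 24.9 percentage points lower from compound 2 to compound 3 (beyond the scatter), and compound 1 lies furthest away, separated by a number 73.2 percentage points lower from compound 1 to compound 3 (beyond the scatter). Both gaps are beyond the usual scatter, so the number for compound 3 is the lowest of the set.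

Compound 4, `O=C(/C=C(O)/C=C/c1ccc(O)cc1O)c1ccccc1O`, has not yet been measured. It differs from compound 3 in one place: hydroxy in place of hydrogen on an aromatic carbon. For the measured compounds named here, the only step already seen that adds or removes a hydroxy on an aromatic carbon is a number 73.2 percentage points lower from compound 1 to compound 3 (beyond the scatter), a large loss when that hydroxy is removed. The hydroxy in compound 4 enters at another place on the ring, so the step cannot simply be copied, but it is the closest guide and points upward. The step of a number 24.9 percentage points lower from compound 2 to compound 3 (beyond the scatter) concerns a chloro group and bears on compound 4 only in showing that one small change on either ring can move the result in this assay by a modest to a large amount.

The expectation for compound 4 is therefore a rise of a number 34.6 percentage points higher from compound 3 to compound 4 (beyond the scatter). Compound 4 is estimated at 55%, within a range from 25% to 85%.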

Compound 4, a percentage reported as inhibition, at one concentration (the size of the read-out at that concentration, not a potency): 61.2%
For compound 4 the middle estimate is 6.2 percentage points below the measured one; the measured number falls inside the stated range.
By their numbers in this assay, from the lowest: compound 3; then compound 2; then compound 4; then compound 1.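

In this assay, the step of a number 40.8 percentage points higher from compound 3 to compound 4 (beyond the scatter) shows that a hydroxy group on the aromatic carbon ortho to a large group and meta to a hydroxy group brings a large gain on its own. For the compounds shown here, the only earlier hydroxy change on this ring was the step of a number 73.2 percentage points lower from compound 1 to compound 3 (beyond the scatter), so the gain could have belonged to that one place alone; the new step shows that, at two different places on this ring, a second hydroxy goes with a higher number, each time beyond the scatter. The data offered here give no explanation for this rise.

On these data alone, it remains open whether the hydroxy group itself matters at this place, or whether a methoxy group, a fluoro group or an amine on the same carbon would give a similar number. As far as these compounds go, it is also open whether the two hydroxy placements would add up in a single compound carrying both, and whether the chloro group of compound 2 would combine with the new hydroxy to give a still higher number.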